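The source may report more compounds than this note shows. Statements on the series, on what has been measured and on what is new or still open speak of the compounds shown alone.

Measured compounds:
- compound 1, `C#CCOc1ccc2oc(=O)ccc2c1` — 24000 nM in a functional assay on A549 cells (Homo sapiens) for cytotoxicity, read by MTT assay, with a stated time of 48 h; a higher number here means a weaker inhibitor, a lower number a stronger inhibitor
- compound 2, `O=c1ccc2cc(OCc3cc(-c4ccc(Cl)cc4)no3)ccc2o1` — "not determined" (no result reported) in this assay
- compound 3, `O=c1ccc2cc(OCc3cn(-c4ccccc4Cl)nn3)ccc2o1` — 17100 nM in this assay

Among the measured compounds shown here, only two numbers stand in this assay. Compound 3 gives 17100 nM and compound 1 gives 24000 nM; the gap between them is within the usual scatter, so neither can be set apart from the other. Compound 2 carries no number in this assay. For the measured compounds named here, no pair of measured compounds differs in a single place, so no measured step is available as a yardstick.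

Compound 4, `COc1ccccc1-n1cc(COc2ccc3oc(=O)ccc3c2)nn1`, is not yet measured. It differs from compound 3 by methoxy in place of chloro on an aromatic carbon. Both measured numbers in this assay sit in the same weak range, and nothing measured speaks for a large effect of such an exchange, so the expected step from compound 3 to compound 4 is a 1.1-fold higher number from compound 3 to compound 4 (0.02 log units; within the scatter), none beyond the scatter. Compound 4 is thus estimated at 18000 nM, with a range from 8000 nM to 45000 nM.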

Compound 4, half-maximal inhibitory concentration: 18700 nM
Compound 4: the middle estimate sits 1.0-fold (0.02 log units) below what was measured; measured number inside the range.
By their numbers in this assay, from the lowest: compounds 3, 4 and 1 (each within the scatter of the next).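

In this assay, among the compounds shown here, the exchange of 2-chlorophenyl for 2-methoxyphenyl gives a 1.1-fold higher number from compound 3 to compound 4 (0.04 log units; within the scatter) and is the only single-place step so far. At this place, on an aromatic carbon ortho to a large group, chloro and methoxy cannot be told apart by this read-out, even though methoxy brings a hydrogen-bond acceptor that chloro lacks. No measurement at hand offers an explanation for this result.

As far as these compounds go, whether a different group at this place, such as an amine, a carboxylic acid or a longer alkoxy chain, would shift the number beyond the scatter remains open. Also open, from the compounds shown here alone, is whether chloro or methoxy elsewhere on the same six-membered aromatic ring would read any differently.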